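Cytotoxicity Limits and One Untested Change to Compound 2

The source may hold more compounds than are shown below. What is called first, only, known or untested is meant among the compounds shown, and "the series" means these compounds.

Of the compounds shown here, three have been tested in an ADME assay on HEK-293T cells (Homo sapiens) for cytotoxicity, read by CCK-8 assay, with a stated time of 48 h (on this read-out lower numbers stand for stronger inhibition and higher numbers for weaker inhibition), and each returned only a limit. Compound 1 `COc1ccc(Oc2ccccc2-c2ccsc2S(=O)(=O)N2CCN(C(=S)Nc3ccc([N+](=O)[O-])cc3)CC2)cc1OC` gives > 20000 nM, a limit and not a number. Compound 2 `COc1ccc(NC(=O)NCCNS(=O)(=O)c2sccc2-c2ccc(C)cc2Oc2ccc(O)c(O)c2)cc1` gives > 20000 nM, likewise a limit. Compound 3 `O=C(Nc1ccc([N+](=O)[O-])cc1)N1CCN(S(=O)(=O)c2sccc2-c2ccccc2Oc2ccc(O)c(O)c2)CC1` gives > 20000 nM, again a limit. Compound 2 therefore stands with the other two, and the whole picture is the limit of > 20000 nM in this assay, at which 3 of the 3 values shown sit. Compound 4 `Cc1ccc(-c2ccsc2S(=O)(=O)NCCNC(=S)Nc2cccc([N+](=O)[O-])c2)c(Oc2ccc(O)c(O)c2)c1` differs from compound 2 by a group of 12 heavy atoms (7 carbon, 2 nitrogen, 2 oxygen, 1 sulfur; one six-membered aromatic ring of carbon only) in place of a group of 11 heavy atoms (8 carbon, 1 nitrogen, 2 oxygen; one six-membered aromatic ring of carbon only), on an amine nitrogen, on an amine nitrogen. Among the measured compounds shown here, no measured step offers a guide to this change. In this assay, the expected shift is a step that the limit leaves unreadable from compound 2 to compound 4, which is none beyond the scatter. For compound 4 the estimate is 25000 nM, with an expected range of 10000 nM to 50000 nM.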

Compound 4, half-maximal inhibitory concentration: 7900 nM
Compound 4: the middle estimate sits 3.2-fold (0.50 log units) above what was measured; measured number below the stated range.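

In this assay, among the compounds shown here, the amine nitrogen on the saturated chain proves to be a place where a change can bring a measured number, something the earlier compounds, all at the limit, did not show, with an at least 2.5-fold lower number from compound 2 to compound 4 (0.40 log units; beyond the scatter). That step gives only a minimum size, since compound 2 holds a limit and not a number: the limit of > 20000 nM in this assay, at which 3 of the 4 values shown sit.

The entering group differs from the (4-methoxyphenyl)carbamoyl group in more than one feature, and the compounds shown do not separate the part played by its sulfur from that of its added nitrogen. As far as these compounds go, what a simple acetyl group or a carboxylic acid would do at this nitrogen also remains open.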